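Ethyl in Place of Fluoro on the Shared Core

The compounds below may be only part of what the source reports. "The series", "measured", "known", "first", "only" and "open" are said of these compounds alone.

Measured so far:
compound 1, `CCOC(=O)c1ccc2oc(N3CCN(C)CC3)nc2c1`, with only a limit, < 4
compound 2, `CN1CCN(c2nc3cc(F)ccc3o2)CC1`, with 5.57

In a functional assay on ileum (strain Hartley) for agonist activity at 5-hydroxytryptamine receptor 3A (Cavia porcellus) (on this read-out lower numbers stand for lower potency and higher numbers for higher potency (the scale is a negative logarithm)), compound 2 holds the only number shown; the other value is a limit, (the limit of < 4 in this assay, at which 1 of the 2 values shown sits). Within the data shown here, the single measured step, a number at least 1.57 log units higher from compound 1 to compound 2 (beyond the scatter), is the one change available for comparison. Compound 3, `CCc1ccc2oc(N3CCN(C)CC3)nc2c1`, differs from compound 2 in one place: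

ethyl in place of fluoro on an aromatic carbon

That change is of a different kind from the one measured, so the step from compound 2 cannot be read across directly; ethyl and ethoxycarbonyl share only that both are larger than fluoro. Compound 3 is therefore expected to lose some potency, with an estimated step of a number 0.57 log units lower from compound 2 to compound 3 (beyond the scatter), and to give about 5, likely between 4 and 5.8, with a real chance that only a limit is reported.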

Compound 3, negative logarithm of the half-maximal effective concentration: < 4
Compound 3: only a limit was reported (the forecaster's own chance of this, stated with the estimate: 20%); middle value at least 1.00 log units away from the limit.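

At this aromatic carbon, ethyl in place of fluoro costs a large amount of potency in this assay: a number at least 1.57 log units lower from compound 2 to compound 3 (beyond the scatter). Compound 3 gives < 4, which is a limit and not a number. The earlier pair tied the loss only to ethoxycarbonyl, whereas ethyl, with no hydrogen-bond acceptors, also leaves no number, so the loss at this position does not depend on the ester group.

The step between compound 1 and compound 3 cannot be read, since both values are limits: the limit of < 4 in this assay, at which 2 of the 3 values shown sit. As far as these compounds go, how far the potency of these two compounds falls past the limit stays open, as does whether a group such as chloro, methyl or methoxy at this carbon would keep a measurable potency as fluoro does.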